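A few compounds are considered here, and "the series" means these few. Any claim that something is new, unique, unknown or untested is made for them only; others in the source may bear on it.

Working notes on the series.

Three analogues share one core and differ only in the aryl group on the ring nitrogen. In a functional assay on A549 cells (Homo sapiens) for antiproliferative activity, read by MTT assay, with a stated time of 72 h (on this read-out lower numbers stand for stronger inhibition and higher numbers for weaker inhibition), compound 1 `NS(=O)(=O)c1ccc(NC(=S)Nc2ccc3ncnc(Nc4cccc(C(F)(F)F)c4)c3c2)cc1` gives 10100 nM, compound 2 `NS(=O)(=O)c1ccc(NC(=S)Nc2ccc3ncnc(Nc4ccc(Cl)c(C(F)(F)F)c4)c3c2)cc1` gives 4500 nM, and compound 3 `NS(=O)(=O)c1ccc(NC(=S)Nc2ccc3ncnc(Nc4cccc(F)c4)c3c2)cc1` gives 25900 nM, the highest of the three numbers; the two steps up to that number are a 2.6-fold higher number from compound 1 to compound 3 (0.41 log units; beyond the scatter) and a 5.8-fold higher number from compound 2 to compound 3 (0.76 log units; beyond the scatter).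

Compound 4 `CCc1ccc(Nc2ncnc3ccc(NC(=S)Nc4ccc(S(N)(=O)=O)cc4)cc23)cc1` takes the next step from compound 3: 4-ethylphenyl in place of 3-fluorophenyl on a nitrogen on an aromatic ring. Both measured steps touching this aryl group moved the read-out beyond the scatter, in the direction of a lower number when the substituent grew from fluoro to trifluoromethyl (a 2.6-fold higher number from compound 1 to compound 3 (0.41 log units; beyond the scatter), read backwards) or to chloro plus trifluoromethyl (a 5.8-fold higher number from compound 2 to compound 3 (0.76 log units; beyond the scatter), read backwards). Among the measured compounds shown here, no measured compound carries an ethyl group or a substituent at this position of the phenyl, so the direction for compound 4 is uncertain; a modest lowering toward the range of compound 1 seems the better guess, with a wide span. Compound 4 is therefore expected at 14000 nM, between 5000 nM and 40000 nM, a step of a 1.9-fold lower number from compound 3 to compound 4 (0.27 log units; within the scatter) from compound 3.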

Compound 4, half-maximal inhibitory concentration: 24600 nM
For compound 4 the middle estimate is 1.8-fold (0.24 log units) below the measured one; low and high end bracket the measured number.
By their numbers in this assay, from the lowest: compound 2; then compound 1; then compounds 4 and 3 (each within the scatter of the next).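

In this assay, the change from 3-fluorophenyl to 4-ethylphenyl on the ring nitrogen gives a 1.1-fold lower number from compound 3 to compound 4 (0.02 log units; within the scatter), so two quite different aryl groups read alike here. Both remain apart from the trifluoromethyl-bearing aryl groups, as shown by a 2.4-fold higher number from compound 1 to compound 4 (0.39 log units; beyond the scatter) and a 5.5-fold higher number from compound 2 to compound 4 (0.74 log units; beyond the scatter); among these four compounds, the lower numbers belong only to compound 1 and compound 2, and ethyl does not reproduce their effect. The data shown offer no measurement that explains this separation.

As far as these compounds go, it remains open whether chloro without trifluoromethyl on the phenyl would also give a lower number, and whether trifluoromethyl itself is what sets compound 1 and compound 2 apart. Also open, from the compounds shown here alone, is how an amine, a carboxylic acid or a chain longer than ethyl on the phenyl would read.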